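Shortening the Ester Chain by One Carbon

The source may hold more compounds than are shown below. What is called first, only, known or untested is meant among the compounds shown, and "the series" means these compounds.

Compound 1 `CCCC(=O)O[C@H]1[C@H](O)[C@H](n2ccc(N)nc2=O)O[C@@H]1CO`, compound 2 `CCCCCCCC/C=C\CCCCCCCC(=O)O[C@H]1[C@H](O)[C@H](n2ccc(N)nc2=O)O[C@@H]1CO` and compound 3 `CCCCCCCCCC(=O)O[C@H]1[C@H](O)[C@H](n2ccc(N)nc2=O)O[C@@H]1CO` share one core and differ only in the ester chain. In a functional assay on HeLa cells (Homo sapiens) for cytotoxicity, read by cell counting, with a stated time of 48 h (on this read-out lower numbers stand for an effect already at smaller amounts and higher numbers for an effect only at larger amounts of compound), compound 1 gives 0.11 ug/mL, compound 2 gives 0.06 ug/mL and compound 3 gives 0.09 ug/mL. On these three numbers compound 3 stands second highest, yet both neighbours sit within the usual scatter: a 1.2-fold lower number from compound 1 to compound 3 (0.09 log units; within the scatter) and a 1.5-fold higher number from compound 2 to compound 3 (0.18 log units; within the scatter). Compound 4 `CCCCCCCCC(=O)O[C@H]1[C@H](O)[C@H](n2ccc(N)nc2=O)O[C@@H]1CO` is not yet measured; its change from compound 3 is hydrogen in place of methyl on a saturated chain carbon, eight bonds along the chain from a carbonyl carbon. Both measured steps also change the length of this same chain and stay within the scatter, so no step beyond the scatter is expected in this assay. Compound 4 is therefore estimated at 0.09 ug/mL, between 0.05 ug/mL and 0.18 ug/mL. The expected step is no change at the digits printed from compound 3 to compound 4 (within the scatter).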

Compound 4, concentration for half-maximal effect: 0.05 ug/mL
The estimate for compound 4 lay 1.8-fold (0.26 log units) above the measured number, and the stated range covers the measured number.
By their numbers in this assay, from the lowest: compounds 4, 2, 3 and 1 (each within the scatter of the next, the first and the last beyond it).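

In this assay hydrogen in place of methyl on a saturated chain carbon, eight bonds along the chain from a carbonyl carbon, gives a 1.8-fold lower number from compound 3 to compound 4 (0.26 log units; within the scatter) and methyl in place of dec-1-en-1-yl gives a 1.2-fold lower number from compound 2 to compound 4 (0.08 log units; within the scatter), so neither step separates the pair. Pentyl in place of hydrogen, three bonds along the chain from a carbonyl carbon, gives a 2.2-fold lower number from compound 1 to compound 4 (0.34 log units; beyond the scatter), the first step in this series to pass the scatter, and only modestly. Nothing measured here explains that difference. On these data alone, whether an ester chain ending in an amine or a carboxylic acid would stay in this range remains open.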